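Swapping Propyl for Ethoxy on the Chain of Compound 2

A few compounds are considered here, and "the series" means these few. Any claim that something is new, unique, unknown or untested is made for them only; others in the source may bear on it.

Measured compounds:
- Compound 1 `CCCCCCCc1cc(=O)c2cc(C(F)(F)F)ccc2[nH]1`: < 5000 nM (a limit)
- Compound 2 `CCCCCCCc1cc(=O)c2cc([N+](=O)[O-])ccc2[nH]1`: < 5000 nM (a limit)
- Compound 3 `CCCCCCCc1cc(OC)c2ccccc2n1`: 5000 nM

In a physicochemical assay for solubility, read by HPLC, at pH 7.4 (a lower number here means a less soluble compound, a higher number a more soluble compound), compound 2 gives < 5000 nM, which is a limit and not a number. Compound 1 gives < 5000 nM, which is also a limit. This shared value is the limit of < 5000 nM in this assay, at which 2 of the 3 values shown sit. Within the data shown here, compound 3 gives 5000 nM, the only actual number in the set.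

The next compound is compound 4 `CCOCCCCc1cc(=O)c2cc([N+](=O)[O-])ccc2[nH]1`. It keeps the nitro group of compound 2 and changes the chain: ethoxy in place of propyl on a saturated chain carbon, four bonds along the chain from an aromatic carbon. In words, ethoxy takes the place of propyl on a saturated chain carbon, four bonds along the chain from an aromatic carbon.

Only one measured step links two of these compounds: a step that the two limits leave unreadable from compound 1 to compound 2. That step concerns a different place in the molecule and has no readable size, so it offers no guide to a change in the chain. With so little to go on, only a modest rise in this assay is expected, and compound 4 may well stay at the limit. The expected change is an at least 1.2-fold higher number from compound 2 to compound 4 (0.07 log units; that floor lies within the scatter). For compound 4 the estimate is 6000 nM, with an expected range from 2000 nM to 20000 nM.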

Compound 4, solubility: 50000 nM
The estimate for compound 4 lay 8.3-fold (0.92 log units) below the measured number; the measured number lies above the stated range.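

Among these compounds, the first step in this set that can be read lies on the chain rather than on the aromatic part of the molecule: in this assay, ethoxy in place of propyl on a saturated chain carbon, four bonds along the chain from an aromatic carbon, gives an at least 10-fold higher number from compound 2 to compound 4 (1.00 log units; beyond the scatter). As far as these compounds go, compound 2 gives < 5000 nM, which is a limit and not a number, so the step is printed as a floor and its true size stays unknown. Propyl and ethoxy each hold 3 heavy atoms, so the groups differ in an oxygen standing where a carbon stood, and this single swap takes compound 4 clear of the limit shared by compound 1 and compound 2: the limit of < 5000 nM in this assay, at which 2 of the 4 values shown sit.

Only this one chain change is shown, so it remains open whether a methoxy group, a longer ether chain or an amine at the same place would give a similar result. From the compounds shown here alone, it is also open whether the same swap would carry over to compound 1, with its trifluoromethyl group, since compound 4 keeps the nitro group of compound 2.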